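Hydroxy to Chloro: Expected Effect

This account rests on a few compounds, and the source may have more. Where it says the series, first, only, none or still open, it means among the compounds named here.

Measured compounds:
compound 1, `COc1ccc(/C=C2\SC(=O)N(Cc3ccc(C)cc3)C2=O)c(OC)c1`: 20.1%
compound 2, `Cc1ccc(CN2C(=O)S/C(=C\c3ccc(O)cc3)C2=O)cc1`: 37.2%

Both were tested in a functional assay on the whole organism (plasma) with Mus musculus as the target, with a stated time of 15 days, at a dose of 40 mg/kg by the oral route; on this read-out lower numbers stand for a weaker effect and higher numbers for a stronger effect at the one dose given. Of the two numbers, compound 2 gives the higher one, and its lead over compound 1 lies beyond the usual scatter, so the two compounds can be told apart. The next compound, compound 3 `Cc1ccc(CN2C(=O)S/C(=C\c3ccc(Cl)cc3)C2=O)cc1`, has not yet been measured in this assay. It differs from compound 2 in one place: chloro in place of hydroxy on an aromatic carbon. Among the compounds with values here, no measured pair in this set shows what this exchange does, so the expectation rests only on the two numbers at hand. Because compound 2 gives 37.2%, compound 3 is expected to stay in the same region, and the estimated step is a number 9.2 percentage points lower from compound 2 to compound 3 (within the scatter), a modest fall that may still lie within the scatter. For compound 3 the estimated value is 28%, with a range from 10% to 48%.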

Compound 3, a percentage reported as activity, at one dose (the size of the read-out at that dose, not a potency): 31.5%
For compound 3 the middle estimate is 3.5 percentage points below the measured one; measured number inside the range.
By their numbers in this assay, from the lowest: compound 1; then compounds 3 and 2 (each within the scatter of the next).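

In this assay, the change from 4-hydroxyphenyl to 4-chlorophenyl gives a number 5.7 percentage points lower from compound 2 to compound 3 (within the scatter), so this single exchange does not separate the two compounds. Hydroxy counts as a hydrogen-bond donor and acceptor and chloro as neither, yet at this position, para to a large group, the two read-outs cannot be told apart, which means a hydrogen-bond donor here is not needed for a number in this region. Nothing available explains why these two groups give such similar numbers.

The compounds shown leave open how an amine, a carboxylic acid or a longer chain such as butoxy would read at this position. They also leave open whether chloro and hydroxy would still read alike at another dose or on a different core.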